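Changing the aryl group on the nitrogen of the core

The source may report more compounds than this note shows. Statements on the series, on what has been measured and on what is new or still open speak of the compounds shown alone.

Measured in a functional assay on PC-9 cells (Homo sapiens) for inhibition, read by MTT assay, with a stated time of 48 h, tested at 10 uM; a higher number here means more inhibition at the concentration tested (going by the name of the read-out), a lower number less inhibition:
compound 1 `Cc1ccc(Nc2cc(NC(=O)Nc3c(Cl)cccc3Cl)ncn2)cc1C` gives 92.1%
compound 2 `COc1cc(NC(=O)Nc2cc(Nc3cccc(C(C)(C)C)c3)ncn2)cc(OC)c1` gives 68%
compound 3 `O=C(Nc1cc(Nc2ccc(F)c(Cl)c2)ncn1)Nc1c(Cl)cccc1Cl` gives 91.1%

Among these three, compound 2 stands lowest, set well apart from both other compounds. Within the data shown here, compound 4 `COc1cc(NC(=O)Nc2cc(Nc3cc(C)cc(F)c3)ncn2)cc(OC)c1` is its close relative: 3-fluoro-5-methylphenyl in place of 3-(tert-butyl)phenyl on a nitrogen on an aromatic ring The one measured step of a similar kind is a number 1 percentage points lower from compound 1 to compound 3 (within the scatter), where exchanging the aryl group on that same nitrogen left the inhibition essentially unchanged. On that basis the change from compound 2 is not expected to move the number beyond the scatter in either direction, so the expected step of a number 4 percentage points higher from compound 2 to compound 4 (within the scatter) is small. Compound 4 is therefore estimated at 72%, with a range from 55% to 89%.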

Compound 4, a percentage reported as inhibition, at one concentration (the size of the read-out at that concentration, not a potency): 64.5%
Estimate against measurement, compound 4: 7.5 percentage points above; the range from low to high includes it.
By their numbers in this assay, from the lowest: compounds 4 and 2 (each within the scatter of the next); then compounds 3 and 1 (each within the scatter of the next).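

The step of a number 3.5 percentage points lower from compound 2 to compound 4 (within the scatter) in this assay shows that this nitrogen also accepts an aryl exchange on a second parent compound, not only on compound 1. Here the exchange replaces 3-(tert-butyl)phenyl, with 10 heavy atoms, with 3-fluoro-5-methylphenyl, with 8 heavy atoms and a fluorine, yet the number stays within the scatter. No supporting data offer a reason for this. Still open, as far as these compounds go, is whether an amine or a carboxylic acid on this aryl ring would leave the number equally undisturbed.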